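Chain extension on the methyl-bearing core

A few compounds are considered here, and "the series" means these few. Any claim that something is new, unique, unknown or untested is made for them only; others in the source may bear on it.

Measured so far in a functional assay on DLD-1 cells (Homo sapiens) for cytotoxicity; on this read-out lower numbers stand for stronger inhibition and higher numbers for weaker inhibition:
compound 1 `N#C/N=C1\N(CCCCCCOc2ccc(Cl)cc2)C(=O)CN1c1ccncc1`: 3440 nM
compound 2 `N#C/N=C1\N(CCCCCCCOc2ccc(Cl)cc2)C(=O)CN1c1ccncc1`: 3340 nM
compound 3 `CC1C(=O)N(CCCCCCOc2ccc(Cl)cc2)/C(=N\C#N)N1c1ccncc1`: 333 nM

Two changes have been made from compound 1. The first, ((4-chlorophenoxy)methyl in place of 4-chlorophenoxy on a saturated chain carbon, six bonds along the chain from an amide-type nitrogen in a ring), gave a 1.0-fold lower number from compound 1 to compound 2 (0.01 log units; within the scatter). The second, (methyl in place of hydrogen on a saturated ring carbon), gave a 10-fold lower number from compound 1 to compound 3 (1.01 log units; beyond the scatter). Compound 3 therefore stands lowest of the three in this assay, with both other compounds beyond the scatter above it.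

Compound 4 `CC1C(=O)N(CCCCCCCOc2ccc(Cl)cc2)/C(=N\C#N)N1c1ccncc1` is not yet measured. Its relation to compound 3 is (4-chlorophenoxy)methyl in place of 4-chlorophenoxy on a saturated chain carbon, six bonds along the chain from an amide-type nitrogen in a ring. This is the same change as that from compound 1 to compound 2, made on the core of compound 3 instead of the core of compound 1; the two cores differ by methyl in place of hydrogen on a saturated ring carbon, and the place of the chain change is described in the same words for both pairs.

For compound 4 the expected step is a 1.0-fold higher number from compound 3 to compound 4 (0.01 log units; within the scatter), an estimate that rests on compound 1 and compound 2, where the same change gave a 1.0-fold lower number from compound 1 to compound 2 (0.01 log units; within the scatter). Whether the chain change behaves the same way on the core that carries the methyl group is not shown by any measured pair, so the range is kept wide. Compound 4 is estimated at 340 nM in this assay, with a likely span from 150 nM to 800 nM.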

Compound 4, half-maximal inhibitory concentration: 370 nM
Beside the measured number, compound 4's estimate is 1.1-fold (0.04 log units) below it, and the stated range covers the measured number.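

In this assay, the chain change on the methyl-bearing core gave a 1.1-fold higher number from compound 3 to compound 4 (0.05 log units; within the scatter), which agrees with the step on the core of compound 1: the same change on two cores in this assay, a 1.0-fold lower number (0.01 log units; within the scatter) from compound 1 to compound 2 and a 1.1-fold higher number (0.05 log units; within the scatter) from compound 3 to compound 4, 1.1-fold (0.06 log units) apart, within the scatter of two such steps. Read the other way, methyl in place of hydrogen on the saturated ring carbon gave a 9.0-fold lower number from compound 2 to compound 4 (0.96 log units; beyond the scatter) with the (4-chlorophenoxy)methyl chain end, and this too agrees with the earlier step: the same change on two cores in this assay, a 10-fold lower number (1.01 log units; beyond the scatter) from compound 1 to compound 3 and a 9.0-fold lower number (0.96 log units; beyond the scatter) from compound 2 to compound 4, 1.1-fold (0.06 log units) apart, within the scatter of two such steps. The two changes therefore carried from one core to the other in these four compounds with no sign that either depends on the other, but this rests on a single pair for each change, in one assay, and what carried over for the chain change is a step within the scatter, so it does not show that larger chain effects would transfer in the same way.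

Going by these compounds, it remains open whether a longer chain, such as one ending in 2-(4-chlorophenoxy)ethyl, would keep the numbers level on either core, and whether ethyl in place of methyl on the saturated ring carbon would retain the step seen with methyl. Also open, on these data alone, is how an amine or a carboxylic acid at the chain end would behave on the methyl-bearing core.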